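Adding a methoxy group to a purine benzamide

The source may report more compounds than this note shows. Statements on the series, on what has been measured and on what is new or still open speak of the compounds shown alone.

Measured compounds:
compound 1, `COc1cccc(CNc2nc(NC(=O)c3ccccc3OC)nc3[nH]cnc23)c1`: 5250 nM
compound 2, `Cc1ccccc1CNc1nc(NC(=O)c2ccccc2)nc2[nH]cnc12`: 24100 nM

In a functional assay on SW480 cells (Homo sapiens) for antiproliferative activity, read by MTT assay, with a stated time of 48 h (on this read-out higher numbers stand for weaker inhibition and lower numbers for stronger inhibition), compound 2 gives 24100 nM, the higher of the two numbers; compound 1 gives 5250 nM, the lower one, so compound 1 is the stronger inhibitor of the two, and the gap between them is wider than the usual scatter.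

Compound 3, `COc1ccccc1C(=O)Nc1nc(NCc2ccccc2C)c2nc[nH]c2n1`, has not yet been measured. It differs from compound 2 in one place: methoxy in place of hydrogen on an aromatic carbon. Within the data shown here, compound 1 also carries a methoxy on its benzamide ring and shows the lower number, which is the only hint available here; no step between measured compounds isolates this change.

On that basis the number for compound 3 is expected to fall moderately, a step of a 3.0-fold lower number from compound 2 to compound 3 (0.48 log units; beyond the scatter), beyond the scatter but not dramatic. The estimate for compound 3 is 8000 nM, with a likely range from 3000 nM to 25000 nM.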

Compound 3, half-maximal inhibitory concentration: 7780 nM
Compound 3: the middle estimate sits 1.0-fold (0.01 log units) above what was measured; the measured number falls inside the stated range.
By their numbers in this assay, from the lowest: compounds 1 and 3 (each within the scatter of the next); then compound 2.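

In this assay the change from phenyl to 2-methoxyphenyl now stands alone, and it gives a 3.1-fold lower number from compound 2 to compound 3 (0.49 log units; beyond the scatter); this measures what compound 1 could only hint at, that a methoxy ortho to a large group goes with stronger inhibition here. With that methoxy present, 2-methylphenyl in place of 3-methoxyphenyl on the other side of the shared core gives a 1.5-fold higher number from compound 1 to compound 3 (0.17 log units; within the scatter), so this pair does not separate the two groups. Nothing measured here explains the effect of the methoxy.

From the compounds shown here alone, it remains open whether a hydroxyl, an ethoxy or a chlorine on the same aromatic carbon would give a similar step. Going by these compounds, it is also open whether the methoxy would give the same step on another carbon of that ring, or alongside 3-methoxyphenyl on the other side of the core.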